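Quinoline amides, antiproliferative series: notes toward compound 4

A few compounds are considered here, and "the series" means these few. Any claim that something is new, unique, unknown or untested is made for them only; others in the source may bear on it.

Measured so far:
compound 1, `Cc1cc(NCCN(C)C)nc2ccc(NC(=O)c3ccc(Cl)c(Cl)c3)cc12`: 2550 nM
compound 2, `CCN1CCN(c2cc(C)c3cc(NC(=O)c4cccc(Cl)c4)ccc3n2)CC1`: 3820 nM
compound 3, `Cc1cc(N(C)C)nc2ccc(NC(=O)c3ccc(Cl)c(Cl)c3)cc12`: 33300 nM

All three numbers come from a functional assay on MCF7 cells (Homo sapiens) for antiproliferative activity, read by MTT assay, with a stated time of 72 h; a lower number here means a stronger inhibitor, a higher number a weaker inhibitor. Compound 2 stands second highest of the three; compound 1 sits within the scatter of it, while compound 3 lies beyond the scatter above it. Going by the values given here, the one single-point step in the set, a 13-fold higher number from compound 1 to compound 3 (1.12 log units; beyond the scatter), concerns the amine on the shared core, not the aryl amide.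

Compound 4, `CCc1ccc(C(=O)Nc2ccc3nc(N4CCN(CC)CC4)cc(C)c3c2)cc1`, differs from compound 2 only in the amide aryl group: 4-ethylphenyl in place of 3-chlorophenyl on a carbonyl carbon. Among the compounds with values here, no measured step touches that part of the molecule, so nothing here anchors the direction. The step from compound 2 is therefore expected to stay within the scatter, a 1.0-fold higher number from compound 2 to compound 4 (0.02 log units; within the scatter). Compound 4 is estimated at 4000 nM, with a range from 1300 nM to 12000 nM.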

Compound 4, half-maximal inhibitory concentration: 3060 nM
Compound 4: middle estimate off by 1.3-fold (0.12 log units), on the high side; the measured number falls inside the stated range.
By their numbers in this assay, from the lowest: compounds 1, 4 and 2 (each within the scatter of the next); then compound 3.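

Going by these compounds alone, this is the first measured step at the amide aryl group: in this assay, 4-ethylphenyl in place of 3-chlorophenyl on a carbonyl carbon gives a 1.2-fold lower number from compound 2 to compound 4 (0.10 log units; within the scatter) and so stays within the scatter. At this position, the pair does not separate the two aryl groups, although they differ in chlorine and ethyl. No available evidence bears on this result.

On these data alone, whether a carboxylic acid or an amine on this aryl ring would keep the number in the same range remains open. So does the effect of a longer chain in place of ethyl.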